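A few compounds are considered here, and "the series" means these few. Any claim that something is new, unique, unknown or untested is made for them only; others in the source may bear on it.

Compound 1 `Cn1nc(COc2cc(F)cc(F)c2)c2c1CCN(C(=O)Nc1ccc(Cl)cc1)C2` is the reference point here. In an assay on cells for inhibition of Pendrin (Mus musculus), read by fluorescence, with a stated time of 10 min (a higher number here means a weaker inhibitor, a lower number a stronger inhibitor), compound 1 gives 3100 nM, the only number shown for the set. Compound 2 `CCOC(=O)c1nn(C)c2c1CN(C(=O)Nc1ccc(Cl)cc1)CC2` gives > 10000 nM in this assay, which is a limit rather than a number (the limit of > 10000 nM in this assay, at which 1 of the 2 values shown sits). Among the measured compounds shown here, the one measured step, an at least 3.2-fold higher number from compound 1 to compound 2 (0.50 log units; beyond the scatter), touches a different part of the shared core from the change now in question. Compound 3 `Cn1nc(COc2cc(F)cc(F)c2)c2c1CCN(C(=O)Nc1ccc(Br)cc1)C2` differs from compound 1 by bromo in place of chloro on an aromatic carbon. For the measured compounds named here, no measured step bears on this exchange of one halogen for another, and the step from compound 1 to compound 2 offers no guidance on it. Compound 3 is therefore expected to sit close to compound 1, with a step of a 1.0-fold lower number from compound 1 to compound 3 (0.01 log units; within the scatter) that stays within the scatter. The estimate for compound 3 in this assay is 3000 nM, expected to fall between 1500 nM and 6500 nM.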

Compound 3, half-maximal inhibitory concentration: 3300 nM
Estimate against measurement, compound 3: 1.1-fold (0.04 log units) below; measured number inside the range.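

In this assay, the exchange on the aromatic carbon para to a large group gives a 1.1-fold higher number from compound 1 to compound 3 (0.03 log units; within the scatter), so chloro and bromo cannot be told apart at this position. Among the compounds shown here, this is the first reading at the 4-chlorophenyl end of the series: the earlier step concerned the (3,5-difluorophenoxy)methyl group on another part of the shared core, and it lay beyond the scatter, whereas this one does not. Nothing measured here offers a reason for this result.

The two halogens are the only groups shown at this position, so it remains open whether a halogen is needed there at all, or how plain hydrogen, a methoxy group, a nitrile or an amine would read. Moving the bromo to another carbon of the ring is equally untested by the compounds shown.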